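The source may report more compounds than this note shows. Statements on the series, on what has been measured and on what is new or still open speak of the compounds shown alone.

Measured in an ADME assay on HeLa cells (Homo sapiens) for cytotoxicity, read by MTT assay; on this read-out lower numbers stand for stronger inhibition and higher numbers for weaker inhibition:
- Compound 1 `COC(=O)[C@@H]1CCCN1C(=O)CCC(=O)Oc1ccc(C[C@H]2C(=O)OC[C@@H]2Cc2ccc(OC)c(OC)c2)cc1OC`: 145000 nM
- Compound 2 `COc1ccc(C[C@H]2COC(=O)[C@@H]2Cc2ccc(OCc3cn(-c4ccc(F)cc4)nn3)c(OC)c2)cc1OC`: >= 600000 nM (a limit of the assay)
- Compound 3 `CCN(CC)C(=O)CCC(=O)Oc1ccc(C[C@H]2C(=O)OC[C@@H]2Cc2ccc(OC)c(OC)c2)cc1OC`: 213000 nM

In this assay, among the measured compounds shown here, compound 3 gives 213000 nM, which lies within the scatter of compound 1, the only other compound with a true number. Compound 2 reports only a limit, >= 600000 nM.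

Compound 4 `COC(=O)CNC(=O)CCC(=O)Oc1ccc(C[C@H]2C(=O)OC[C@@H]2Cc2ccc(OC)c(OC)c2)cc1OC` has ((methoxycarbonyl)methyl)amino in place of diethylamino on a carbonyl carbon. For the measured compounds named here, one measured step concerns this same place: a 1.5-fold higher number from compound 1 to compound 3 (0.17 log units; within the scatter). That exchange of groups left the number within the scatter, so no larger change is expected here. Compound 1, whose group also holds a methoxycarbonyl, gives 145000 nM, which draws the expectation slightly towards that value. The expected step is small and stays within the scatter: a 1.3-fold lower number from compound 3 to compound 4 (0.10 log units; within the scatter). For compound 4 the estimate in this assay is 170000 nM, with an expected range from 85000 nM to 340000 nM.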

Compound 4, half-maximal inhibitory concentration: 179000 nM
For compound 4 the middle estimate is 1.1-fold (0.02 log units) below the measured one; measured number inside the range.
By their numbers in this assay, from the lowest: compounds 1, 4 and 3 (each within the scatter of the next). At a limit, above all of these: compound 2.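

In this assay, replacing diethylamino with ((methoxycarbonyl)methyl)amino on a carbonyl carbon gives a 1.2-fold lower number from compound 3 to compound 4 (0.08 log units; within the scatter), so adding a hydrogen-bond donor and two hydrogen-bond acceptors at this position leaves the number within the scatter. Opening the ring group also leaves the number within the scatter, with 2-(methoxycarbonyl)pyrrolidin-1-yl giving way to the ring-free ((methoxycarbonyl)methyl)amino in a 1.2-fold higher number from compound 1 to compound 4 (0.09 log units; within the scatter), so all three groups at this position now lie within the scatter of one another. No available measurement bears on why these numbers stay so close.

Going by these compounds, it remains open whether a carboxylic acid in place of the methoxycarbonyl end, or a longer chain ending in a primary amine, would keep the number within the scatter. On these data alone, it also remains open whether any group on this carbonyl carbon can move the number beyond the scatter.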